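This account rests on a few compounds, and the source may have more. Where it says the series, first, only, none or still open, it means among the compounds named here.

Measured compounds:
Compound 1 `Cc1nc(-c2cccnc2)sc1-c1nnc(-c2cccc(Cl)c2Cl)o1`, in an ADME assay on HeLa cells (Homo sapiens) for cytotoxicity, read by MTT assay (a higher number here means that more compound is tolerated, a lower number that less compound is tolerated), gives > 100 ug/mL, which is a limit of the assay rather than a number.
Compound 2 `Cc1nc(-c2cccnc2)sc1-c1nnc(-c2ccc(O)cc2)o1` gives > 100 ug/mL, again a limit rather than a number.

Compound 2 therefore stands at the top of what the assay can report, together with compound 1, as summarised by the limit of > 100 ug/mL in this assay, at which 2 of the 2 values shown sit. For the measured compounds named here, the only measured step, a step that the two limits leave unreadable from compound 1 to compound 2, cannot be sized, since both of its ends are limits.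

Compound 3 `Cc1nc(-c2cccnc2)sc1-c1nnc(-c2cccnc2)o1` differs from compound 2 by pyridin-3-yl in place of 4-hydroxyphenyl on an aromatic carbon. Going by the values given here, no measured step bears directly on this exchange; the one available step gives only two limits. The expectation is that the step that the limit leaves unreadable from compound 2 to compound 3 is nothing beyond the usual scatter, most likely ending in a limit once more. Compound 3 is thus estimated at 150 ug/mL, within a range from 80 ug/mL to 400 ug/mL.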

Compound 3, half-maximal cytotoxic concentration: > 100 ug/mL
Compound 3: only a limit was reported (the forecaster's own chance of this, stated with the estimate: 85%); the middle value lies beyond the limit too.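

No step among compound 1, compound 2 and compound 3 can be read in this assay, since each result is a limit rather than a number: the limit of > 100 ug/mL in this assay, at which 3 of the 3 values shown sit.

The compounds shown leave open what concentration each one tolerates before half-maximal cytotoxicity, and whether exchanging these groups changes it at all.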